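This account rests on a few compounds, and the source may have more. Where it says the series, first, only, none or still open, it means among the compounds named here.

Compound 2 `O=c1[nH]nc(C[S+]([O-])C(c2ccccc2)c2ccccc2)s1`: 38100 nM
Compound 1 `Cc1nnc(C[S+]([O-])C(c2ccccc2)c2ccccc2)s1`: "not active" (no number reported)

Among the measured compounds shown here, in an assay on HEK293 cells for inhibition of sodium-dependent dopamine transporter (Homo sapiens), read by scintillation counting, with stated times of 5 min and 1 min (a higher number here means a weaker inhibitor, a lower number a stronger inhibitor), compound 2 gives 38100 nM, the only number in this set, a weak result. For the measured compounds named here, compound 1 is reported in this assay as "not active" (no number reported), with no number, so no measured step between the two can be stated. Compound 3 `[O-][S+](Cc1ccsc1Br)C(c1ccccc1)c1ccccc1` carries a group of 6 heavy atoms (4 carbon, 1 sulfur, 1 bromine; one five-membered aromatic ring with 1 hetero atom) in place of a group of 6 heavy atoms (2 carbon, 2 nitrogen, 1 oxygen, 1 sulfur; one five-membered aromatic ring with 3 hetero atoms), on a saturated chain carbon bound to a sulfur. Going by the values given here, with no measured step to lean on, the expected step from compound 2 to compound 3 is a modest gain, a 1.9-fold lower number from compound 2 to compound 3 (0.28 log units; within the scatter), not much beyond the scatter. Compound 3 is therefore estimated at 20000 nM, within 4000 nM to 100000 nM.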

Compound 3, half-maximal inhibitory concentration: 29300 nM
Compound 3: middle estimate off by 1.5-fold (0.17 log units), on the low side; low and high end bracket the measured number.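

In this assay, replacing the earlier five-membered ring on the saturated chain carbon bound to a sulfur with 2-bromothiophen-3-yl gives a 1.3-fold lower number from compound 2 to compound 3 (0.11 log units; within the scatter), so compound 2 and compound 3 cannot be told apart. This position therefore tolerates a real change of ring, including the loss of the hydrogen-bond donor, with no measurable difference, and the reading remains weak. No other measurement bears on why the two compounds read alike.

From the compounds shown here alone, what an amine or a carboxylic acid would do at this place remains open. So does the contribution of the bromine within 2-bromothiophen-3-yl.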